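The source may hold more compounds than are shown below. What is called first, only, known or untested is meant among the compounds shown, and "the series" means these compounds.

Compound 3 `O=C1C(Nc2ccc(Br)cc2)=CC(=O)c2c1nc1n2[C@H]2OC[C@@H](O)[C@H]2OC1` gives 1980 nM in a functional assay on ECa-109 cells for inhibition, with ECa-109 cell line (Homo sapiens) as the target, read by sulforhodamine B assay; a lower number here means a stronger inhibitor, a higher number a weaker inhibitor. Compound 2 `Cc1ccc(NC2=CC(=O)c3c(nc4n3[C@H]3OC[C@@H](O)[C@H]3OC4)C2=O)cc1C` gives 4090 nM in this assay. Compound 1 `CCCc1ccc(NC2=CC(=O)c3c(nc4n3[C@H]3OC[C@@H](O)[C@H]3OC4)C2=O)cc1` reaches only a limit of the assay in this assay, namely > 4000 nM, which is the limit of > 4000 nM in this assay, at which 1 of the 3 values shown sits. Of the two numbers that are not limits, compound 3 has the lower one: the step of a 2.1-fold lower number from compound 2 to compound 3 (0.32 log units; beyond the scatter) is modest, and the step of an at least 2.0-fold lower number from compound 1 to compound 3 (0.30 log units; that floor lies within the scatter) can be read only as a floor. The step that the limit leaves unreadable from compound 1 to compound 2 is left unreadable by the limit.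

Compound 4 `O=C1C(Nc2ccc(I)cc2)=CC(=O)c2c1nc1n2[C@H]2OC[C@@H](O)[C@H]2OC1` differs from compound 3 by iodo in place of bromo on an aromatic carbon. Among the compounds with values here, none of the measured steps exchanges one halogen for another. The nearest in kind is the step of a 2.1-fold lower number from compound 2 to compound 3 (0.32 log units; beyond the scatter), in which 4-bromophenyl entered in place of 3,4-dimethylphenyl and brought a modest gain, and the step of an at least 2.0-fold lower number from compound 1 to compound 3 (0.30 log units; that floor lies within the scatter), in which bromo entered in place of propyl. The change to compound 4 exchanges one halogen for another and nothing else, and the expected step is a 1.3-fold lower number from compound 3 to compound 4 (0.12 log units; within the scatter), most likely within the scatter and, if anything, toward a lower number. Compound 4 is therefore estimated at 1500 nM, with a range from 600 nM to 4000 nM.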

Compound 4, half-maximal inhibitory concentration: 2530 nM
Estimate against measurement, compound 4: 1.7-fold (0.23 log units) below, and the stated range covers the measured number.
By their numbers in this assay, from the lowest: compounds 3, 4 and 2 (each within the scatter of the next, the first and the last beyond it).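

Within the data shown here, exchanging one halogen for the other on this aromatic carbon, para to a large group, gives a 1.3-fold higher number from compound 3 to compound 4 (0.11 log units; within the scatter), so in this assay 4-bromophenyl and 4-iodophenyl cannot be told apart, a comparison that the earlier compounds, with only one halogen among them, could not offer. The edge of compound 3 over compound 2 lay just beyond the scatter, but the iodo group does not carry this over: 4-iodophenyl in place of 3,4-dimethylphenyl gives a 1.6-fold lower number from compound 2 to compound 4 (0.21 log units; within the scatter), and iodo in place of propyl gives an at least 1.5-fold lower number from compound 1 to compound 4 (0.19 log units; that floor lies within the scatter). Compound 1 stands at a limit, so this last step can be read only as a floor: the limit of > 4000 nM in this assay, at which 1 of the 4 values shown sits.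

The compounds shown leave open how a smaller halogen such as chloro or fluoro, or a methoxy group or an amine, would read at this same place on the ring. They also leave open whether a change away from the aniline ring, for instance at the hydroxyl group of the shared core, would move the numbers further than any exchange of these aromatic groups has.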